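Removing the Amino Group from Compound 2

The compounds below may be only part of what the source reports. "The series", "measured", "known", "first", "only" and "open" are said of these compounds alone.

Compound 1 `COc1cc(-n2ncnc2-c2ccc(OC(C)C)cc2)cc(OC)c1OC` gives 800 nM in a functional assay on K562 cells (Homo sapiens) for antiproliferative activity, read by MTT assay, with a stated time of 72 h; on this read-out higher numbers stand for weaker inhibition and lower numbers for stronger inhibition. Compound 2 `COc1cc(-c2ncnn2-c2cccc(N)c2)cc(OC)c1OC` is reported in this assay only as a limit, > 10000 nM, and not as a number; (the limit of > 10000 nM in this assay, at which 1 of the 2 values shown sits). On the numbers shown, compound 2 therefore stands at the limit of the assay, with no measured value of its own.

Compound 3 `COc1cc(-c2ncnn2-c2ccccc2)cc(OC)c1OC` differs from compound 2 by hydrogen in place of amino on an aromatic carbon. Within the data shown here, no step between two measured compounds resembles this change, and compound 2 offers no number to build on. The step from compound 2 to compound 3 is expected to be small, a number no higher from compound 2 to compound 3 (the limit leaves the size open), within the scatter. Compound 3 is expected to give about 10000 nM, between 2000 nM and 40000 nM, and may again be reported only as a limit.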

Compound 3, half-maximal inhibitory concentration: > 10000 nM
Compound 3 ended at the assay's limit (the forecaster's own chance of this, stated with the estimate: 55%); the middle value lies on the limit itself.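

Compound 2 and compound 3 both stand only at a limit, so no step between them can be read: the limit of > 10000 nM in this assay, at which 2 of the 3 values shown sit.

On these data alone, whether hydrogen in place of amino changes the activity at all remains open, as does how far either compound lies from that limit.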